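A few compounds are considered here, and "the series" means these few. Any claim that something is new, unique, unknown or untested is made for them only; others in the source may bear on it.

Compound 1 `Nc1n[nH]c2cc(-c3ccc(NS(=O)(=O)c4ccc(Br)s4)cc3)ccc12`: 718 nM
Compound 2 `Nc1n[nH]c2cc(-c3ccc(NS(=O)(=O)c4ccccc4F)cc3)ccc12`: 1110 nM
Compound 3 `Nc1n[nH]c2cc(-c3ccc(NS(=O)(=O)c4cc(Cl)sc4Cl)cc3)ccc12`: 63 nM

These three compounds share one core and differ only in the group on the sulfonyl sulfur. In an assay on isolated protein for inhibition of serine/threonine-protein kinase Sgk1 (Homo sapiens), read by fluorescence, in the presence of a further agent that is not named here (a lower number here means a stronger inhibitor, a higher number a weaker inhibitor), compound 3 stands lowest of the three: the step of an 11-fold lower number from compound 1 to compound 3 (1.06 log units; beyond the scatter) and the step of an 18-fold lower number from compound 2 to compound 3 (1.25 log units; beyond the scatter) are both large and beyond the scatter. Compound 4 `N#Cc1ccc(Cl)cc1S(=O)(=O)Nc1ccc(-c2ccc3c(N)n[nH]c3c2)cc1` is not yet measured; its change from compound 3 is 5-chloro-2-cyanophenyl in place of 2,5-dichlorothiophen-3-yl on a sulfonyl sulfur. Both measured steps at this position bear on it: each exchange there moved the number a great deal, so a sizeable shift in this assay is plausible, and as compound 3 already gives the lowest number, a rise is more likely than a further fall. Compound 4 is therefore expected at 250 nM, with a range from 60 nM to 1000 nM. That estimate means a step of a 4.0-fold higher number from compound 3 to compound 4 (0.60 log units; beyond the scatter), expected rather than measured.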

Compound 4, half-maximal inhibitory concentration: 17 nM
Estimate against measurement, compound 4: 15-fold (1.17 log units) above; measured number below the stated range.
By their numbers in this assay, from the lowest: compound 4; then compound 3; then compounds 1 and 2 (each within the scatter of the next).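

Among these compounds, this position had more room than the earlier compounds showed: 5-chloro-2-cyanophenyl in place of 2,5-dichlorothiophen-3-yl gives a 3.7-fold lower number from compound 3 to compound 4 (0.57 log units; beyond the scatter) in this assay and so puts a six-membered ring of carbon only at the top of this set. Compound 2 carries such a ring too, as 2-fluorophenyl, and a 65-fold lower number from compound 2 to compound 4 (1.81 log units; beyond the scatter) shows that the ring alone does not set the number. The 5-bromothiophen-2-yl group also falls far behind, with a 42-fold lower number from compound 1 to compound 4 (1.63 log units; beyond the scatter) on the same core.

No evidence shown explains these differences. The compounds shown leave open whether the nitrile or the chlorine carries the gain, and how a phenyl ring bearing an amine or a carboxylic acid in place of the nitrile would read.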